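A few compounds are considered here, and "the series" means these few. Any claim that something is new, unique, unknown or untested is made for them only; others in the source may bear on it.

Measured so far:
Compound 1 `N#Cc1ccc(NCc2cncn2Cc2ccc(-c3ccccc3)cc2)cc1-c1ccccc1`: > 1000 nM
Compound 2 `O=C(c1ccc(NCc2cncn2Cc2ccc(-c3ccccc3)cc2)cc1-c1ccccc1)N1CCCCC1`: > 1000 nM
Compound 3 `c1ccc(-c2ccc(Cn3cncc3CNc3ccc(-c4nc5ccccc5s4)c(-c4ccccc4)c3)cc2)cc1`: > 1000 nM

These results come from a toxicity assay on NIH3T3 cells (Mus musculus) for cytotoxicity, read by resazurin assay; a higher number here means that more compound is needed for the effect, a lower number that less compound is needed. Compound 3 stands at > 1000 nM, which is a limit and not a number. It shares that position with the other two compounds: the limit of > 1000 nM in this assay, at which 3 of the 3 values shown sit.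

Compound 4 `CC(C)OC(=O)c1ccc(NCc2cncn2Cc2ccc(-c3ccccc3)cc2)cc1-c1ccccc1` differs from compound 3 by one swap: isopropoxycarbonyl in place of 1,3-benzothiazol-2-yl on an aromatic carbon. For the measured compounds named here, the steps that bear on it are changes on the same aromatic carbon: a step that the two limits leave unreadable from compound 1 to compound 2, a step that the two limits leave unreadable from compound 1 to compound 3 and a step that the two limits leave unreadable from compound 2 to compound 3. None has a readable size, and none gives a direction, so no step beyond the scatter is expected in this assay. The expected change is a step that the limit leaves unreadable from compound 3 to compound 4, an estimate only. Compound 4 is expected at about 3000 nM, with an estimated range of 1000 nM to 10000 nM.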

Compound 4, half-maximal effective concentration: > 10000 nM
Compound 4 was reported as a limit; the forecaster's own chance of this, stated with the estimate: 85%; middle value at least 3.3-fold (0.52 log units) away from the limit.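

For the compounds shown here, compound 1, compound 2, compound 3 and compound 4 all stand as limits in this assay, and no step among them can be read. On these data alone, how much of each compound is needed for the effect, and whether swapping these groups changes that amount, stays open.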